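Trading a hydroxy for an aldehyde on the shared core

A few compounds are considered here, and "the series" means these few. Any claim that something is new, unique, unknown or untested is made for them only; others in the source may bear on it.

Compound 1 `COc1cccc(Sc2c(NS(=O)(=O)c3ccc(C(C)(C)C)cc3)noc2CO)c1`, compound 2 `COc1cccc(Sc2c(NS(=O)(=O)c3ccc(C(C)(C)C)cc3)noc2CCCC(N)=O)c1` and compound 3 `COc1cccc(Sc2c(NS(=O)(=O)c3ccc(C(C)(C)C)cc3)noc2CCCC(C)=O)c1` share one core and differ only in the group on a saturated chain carbon bound to an aromatic carbon. In an assay on A7R5 cells for displacement of a labelled ligand from Endothelin-1 receptor (Rattus norvegicus) (a higher number here means a weaker inhibitor, a lower number a stronger inhibitor), compound 1 gives 6200 nM, the second highest of the three numbers. Compound 2 gives 6300 nM and compound 3 gives 1300 nM. The step of a 1.0-fold higher number from compound 1 to compound 2 (0.01 log units; within the scatter) stays within the scatter, whereas a 4.8-fold lower number from compound 1 to compound 3 (0.68 log units; beyond the scatter) and a 4.8-fold lower number from compound 2 to compound 3 (0.69 log units; beyond the scatter) are modest gains. Compound 4 `COc1cccc(Sc2c(NS(=O)(=O)c3ccc(C(C)(C)C)cc3)noc2CCC=O)c1` carries formylmethyl in place of hydroxy on a saturated chain carbon bound to an aromatic carbon. Within the data shown here, because a 4.8-fold lower number from compound 1 to compound 3 (0.68 log units; beyond the scatter) came with a carbonyl entering the chain and no donor, a modest downward step is expected for compound 4, though its chain is shorter and no measured pair tests that length. Compound 4 is therefore estimated at 2500 nM, a step of a 2.5-fold lower number from compound 1 to compound 4 (0.39 log units; beyond the scatter), with a range from 1000 nM to 7000 nM.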

Compound 4, half-maximal inhibitory concentration: 380 nM
Beside the measured number, compound 4's estimate is 6.6-fold (0.82 log units) above it, outside the stated range (below it).
By their numbers in this assay, from the lowest: compound 4; then compound 3; then compounds 1 and 2 (each within the scatter of the next).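

Ending the chain in 2-formylethyl does far more than the earlier changes at this position, giving a 16-fold lower number from compound 1 to compound 4 (1.21 log units; beyond the scatter) and a 17-fold lower number from compound 2 to compound 4 (1.22 log units; beyond the scatter). Even against the ketone chain of compound 3, the step is a 3.4-fold lower number from compound 3 to compound 4 (0.53 log units; beyond the scatter), so what sits at the chain end, or the chain's length, matters here. A carbonyl alone does not account for the pattern, as compound 2 also carries one yet stays within the scatter of compound 1.

From the compounds shown here alone, whether the formyl group or the chain length matters more stays open, and so does how a longer chain ending in formyl, a carboxylic acid or an amine would compare. Nothing available here explains the gain.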